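Thiophene-to-furan swap on a nucleoside core

The source may report more compounds than this note shows. Statements on the series, on what has been measured and on what is new or still open speak of the compounds shown alone.

Measured so far in a functional assay on HCT-116 cells (Homo sapiens), read by MTT assay, with a stated time of 72 h; on this read-out higher numbers stand for weaker inhibition and lower numbers for stronger inhibition:
compound 1 `COc1nc(N)nc2c1c(-c1cccs1)cn2[C@@H]1O[C@H](CO)[C@@H](O)[C@H]1O`: > 20000 nM
compound 2 `Nc1nc2c(c(-c3cccs3)cn2[C@@H]2O[C@H](CO)[C@@H](O)[C@H]2O)c(=O)[nH]1`: > 20000 nM
compound 3 `COc1nc(N)nc2c1c(-c1ccoc1)cn2[C@@H]1O[C@H](CO)[C@@H](O)[C@H]1O`: > 20000 nM

Each of these three values is a limit of the assay, not a number. Compound 1 turns into compound 3 by furan-3-yl in place of thiophen-2-yl on an aromatic carbon; the step that the two limits leave unreadable from compound 1 to compound 3 cannot be read because of the limit of > 20000 nM in this assay, at which 3 of the 3 values shown sit. The cores of compound 1 and compound 2 differ, but that difference is not broken down here. Compound 4 `Nc1nc2c(c(-c3ccoc3)cn2[C@@H]2O[C@H](CO)[C@@H](O)[C@H]2O)c(=O)[nH]1` is not yet measured; it arises from compound 2 by furan-3-yl in place of thiophen-2-yl on an aromatic carbon, the same change as from compound 1 to compound 3, at the same place. Since compound 2 sits at the limit with > 20000 nM, compound 4 is expected to stay there as well, an expected step that the limit leaves unreadable from compound 2 to compound 4. The estimate for compound 4 is 30000 nM, between 15000 nM and 100000 nM.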

Compound 4, half-maximal inhibitory concentration: 14200 nM
For compound 4 the middle estimate is 2.1-fold (0.32 log units) above the measured one; the measured number lies below the stated range.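

In this assay, furan-3-yl in place of thiophen-2-yl gives an at least 1.4-fold lower number from compound 2 to compound 4 (0.14 log units; that floor lies within the scatter), and compound 4 is the only compound shown with a measured number, 14200 nM. As far as these compounds go, because only a lower bound on this step is known, its true size stays open, and that bound alone does not show a real gain. The same change on the core of compound 1 cannot be read, so nothing shows whether the change carries from one core to the other, for this reason: the limit of > 20000 nM in this assay, at which 3 of the 4 values shown sit.

The compounds shown leave open whether the ring's oxygen or its point of attachment matters, a question that furan-2-yl or thiophen-3-yl on the core of compound 2 could address. From the compounds shown here alone, how an amine or a carboxylic acid in place of furan-3-yl would read in this assay also remains open.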